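A few compounds are considered here, and "the series" means these few. Any claim that something is new, unique, unknown or untested is made for them only; others in the source may bear on it.

Compound 2 `C=CCn1c(=O)/c(=C\c2cc(F)ccc2C)[nH]c(=O)/c1=C\c1ccccc1OC` holds the only number shown: in a functional assay on BGC-823 cells (Homo sapiens) for cytotoxicity, read by CCK-8 assay, with a stated time of 72 h (on this read-out lower numbers stand for stronger inhibition and higher numbers for weaker inhibition), compound 2 gives 1600 nM. Compound 1 `C=CCn1c(=O)/c(=C\c2ccc(C)cc2)[nH]c(=O)/c1=C\c1ccccc1OC` is the other entry; in this assay compound 1 gives "not active" (no number reported), and no single number was reported for it. Compound 3 `C=CCn1c(=O)/c(=C\c2ccccc2F)[nH]c(=O)/c1=C\c1ccccc1OC` has not been measured. It differs from compound 2 in one exchange: 2-fluorophenyl in place of 5-fluoro-2-methylphenyl on a double-bonded chain carbon bound to an aromatic carbon. Among the measured compounds shown here, no measured pair shows what such a change does, so the size of the step is unknown. A modest weakening beyond the scatter is expected, a 2.2-fold higher number from compound 2 to compound 3 (0.34 log units; beyond the scatter). Compound 3 is therefore estimated at 3500 nM, within a range from 900 nM to 15000 nM.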

Compound 3, half-maximal inhibitory concentration: 18900 nM
Compound 3: the middle estimate sits 5.4-fold (0.73 log units) below what was measured; measured number above the stated range.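

In this assay, the exchange of 5-fluoro-2-methylphenyl for 2-fluorophenyl gives a 12-fold higher number from compound 2 to compound 3 (1.07 log units; beyond the scatter) and so shows that the aromatic group at this position strongly affects the read-out. The two groups differ in more than one feature, so this single pair cannot tie the loss to any one of them. Nothing available explains the size of the step. Still open, on these data alone, is what 2-methylphenyl would give at this position, which would help separate the two features. Also open, as far as these compounds go, is how an amine or a carboxylic acid on this ring would behave.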